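Replacing a Pyrrolidine Ring with a Methylamino Group

The compounds below may be only part of what the source reports. "The series", "measured", "known", "first", "only" and "open" are said of these compounds alone.

Measured compounds:
compound 1, `CC1CCCCC1Oc1cccc2ccc(N)nc12`: 1330 nM
compound 2, `Nc1ccc2cccc(OC3CCCCCC3)c2n1`: 3480 nM
compound 3, `CC(CC(C)(C)C)Oc1cccc2ccc(N3CCCC3)nc12`: > 10000 nM

All three were tested in a functional assay on IMR-32 cells with melanin-concentrating hormone receptor 1 (Homo sapiens) as the target, read by fluorescence; on this read-out higher numbers stand for weaker inhibition and lower numbers for stronger inhibition. Compound 1 gives 1330 nM, and compound 2 gives 3480 nM; both carry a plain amino group on the shared core. For compound 3 the assay reports only a limit, > 10000 nM, and not a number, a point made by the limit of > 10000 nM in this assay, at which 1 of the 3 values shown sits. Compound 3 therefore stands at the edge of what this assay can read, whereas compounds 1 and 2 return measured numbers well inside its range.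

Compound 4, `CNc1ccc2cccc(OC(C)CC(C)(C)C)c2n1`, has not yet been measured. It differs from compound 3 in a single place: methylamino in place of pyrrolidin-1-yl on an aromatic carbon. The change brings back a hydrogen-bond donor of the kind that compound 1 and compound 2 carry, and both of those return measured values rather than a limit, whereas compound 3, with pyrrolidin-1-yl, does not. In this assay, for the measured compounds named here, a step of an at least 4.0-fold lower number from compound 3 to compound 4 (0.60 log units; beyond the scatter) toward stronger inhibition is therefore expected, larger than the usual scatter, though the branched alkoxy chain of compound 4 has no measured counterpart here and the expectation is correspondingly uncertain. Compound 4 is estimated to give 2500 nM, with a likely range from 600 nM to 10000 nM.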

Compound 4, half-maximal inhibitory concentration: 6090 nM
Compound 4: the middle estimate sits 2.4-fold (0.39 log units) below what was measured; low and high end bracket the measured number.
By their numbers in this assay, from the lowest: compound 1; then compounds 2 and 4 (each within the scatter of the next). At a limit, above all of these: compound 3.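

In this assay, methylamino in place of pyrrolidin-1-yl on this aromatic carbon, next to the ring nitrogen, gives an at least 1.6-fold lower number from compound 3 to compound 4 (0.21 log units; that floor lies within the scatter). For the compounds shown here, this is the first sign that the group on this carbon can decide whether a compound with the branched alkoxy chain returns a number at all, since compound 4 gives a measured value where compound 3 does not. The real size of the step stays unknown, and its floor alone cannot show a change beyond the scatter, because compound 3 is recorded only as a limit: the limit of > 10000 nM in this assay, at which 1 of the 4 values shown sits.

The swap removes a ring and adds a hydrogen-bond donor in one move, so these compounds cannot say which of the two matters. A dimethylamino group on the same chain would keep the ring-free shape without the donor, while a plain amino group on that chain would link compound 4 to the amino compounds, which differ from it in more than one place.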